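A few compounds are considered here, and "the series" means these few. Any claim that something is new, unique, unknown or untested is made for them only; others in the source may bear on it.

Three compounds sharing one core were tested in a functional assay on 143B cells (Homo sapiens) for inhibition, read by MTT assay, with a stated time of 72 h (on this read-out lower numbers stand for stronger inhibition and higher numbers for weaker inhibition), and gave close numbers: compound 1 (`O=C(CCC(=O)OCCCCCCSc1ccc([N+](=O)[O-])c2nonc12)Nc1ccccc1Cl`) reads 2430 nM there, compound 2 (`Cc1ccccc1NC(=O)CCC(=O)OCCCCCCSc1ccc([N+](=O)[O-])c2nonc12`) reads 4660 nM there, and compound 3 (`COc1ccc(NC(=O)CCC(=O)OCCCCCCSc2ccc([N+](=O)[O-])c3nonc23)cc1OC`) reads 2770 nM there. Compound 3 is not set apart from the other two: the data show a 1.1-fold higher number from compound 1 to compound 3 (0.06 log units; within the scatter) and also a 1.7-fold lower number from compound 2 to compound 3 (0.23 log units; within the scatter) for it, while the remaining pair shows a 1.9-fold higher number from compound 1 to compound 2 (0.28 log units; within the scatter) in the same series.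

Compound 4 (`CCN(CC)CCCNC(=O)CCC(=O)OCCCCCCSc1ccc([N+](=O)[O-])c2nonc12`) takes a larger structural step, 3-(diethylamino)propyl in place of 3,4-dimethoxyphenyl on an amide-type nitrogen in full, which is 3-(diethylamino)propyl in place of 3,4-dimethoxyphenyl on an amide-type nitrogen. The measured steps that bear on it are the two changes of group on that nitrogen, the step to compound 3 from compound 1 and the step to compound 3 from compound 2, and neither goes beyond the scatter. All three measured compounds carry a ring on that nitrogen, however, so they are only a weak guide to a group without one. No shift beyond the scatter is expected, and the estimate means a 1.1-fold higher number from compound 3 to compound 4 (0.03 log units; within the scatter) in this read-out, with no firm direction. In this assay compound 4 is estimated at 3000 nM with 1000 nM to 9000 nM as the expected range.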

Compound 4, half-maximal inhibitory concentration: 3440 nM
Compound 4: the middle estimate sits 1.1-fold (0.06 log units) below what was measured; measured number inside the range.
By their numbers in this assay, from the lowest: compounds 1, 3, 4 and 2 (each within the scatter of the next).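

Compound 4 alone among the four carries no ring on the amide-type nitrogen, and 3-(diethylamino)propyl brings a nitrogen that none of the three earlier groups there holds. Even so, in this assay all three new comparisons stay within the scatter (a 1.2-fold higher number from compound 3 to compound 4 (0.09 log units; within the scatter); a 1.4-fold lower number from compound 2 to compound 4 (0.13 log units; within the scatter); a 1.4-fold higher number from compound 1 to compound 4 (0.15 log units; within the scatter)), so the insensitivity to the group on that nitrogen, seen before only among substituted phenyl groups, now also covers an open chain ending in a tertiary amine. Nothing available here accounts for this lack of change, and no measurement beyond these numbers bears on it.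

The compounds shown leave open whether the same holds for a quite different end group on that nitrogen, such as a carboxylic acid, a primary amine or a much longer chain, or for the amide hydrogen replaced by methyl. The rest of the molecule is the same in all four compounds, so they say nothing about what a shorter chain on the sulfur or a change to the shared core would do to the number in this assay.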